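This account rests on a few compounds, and the source may have more. Where it says the series, first, only, none or still open, it means among the compounds named here.

Notes on the series.

Compound 1 `O=C(Nc1ccccc1)c1cc2ccccc2oc1=O` is the parent of the set; in an assay on isolated protein for inhibition of coagulation factor XII (Homo sapiens) (a lower number here means a stronger inhibitor, a higher number a weaker inhibitor), compound 1 gives 42000 nM. Compound 2 `Cc1ccc2oc(=O)c(C(=O)Nc3ccccc3)cc2c1` carries a methyl on the carbon-only aromatic ring of the shared core; in this assay compound 2 gives 23000 nM. Within the data shown here, the one step measured so far, a 1.8-fold lower number from compound 1 to compound 2 (0.26 log units; within the scatter), stays within the scatter, so the two numbers available cannot be told apart, and compound 2 stands level with compound 1 rather than ahead of it.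

Compound 3 `O=C(Nc1ccccc1)c1cc2cc([N+](=O)[O-])ccc2oc1=O` has not been measured. It differs from compound 2 in one place: nitro in place of methyl on an aromatic carbon. Only a 1.8-fold lower number from compound 1 to compound 2 (0.26 log units; within the scatter) touches the same position, and it shows that a small change there left the number unmoved beyond the scatter. Among the measured compounds shown here, no step in the set involves a nitro group, so nothing measured speaks for a shift in either direction. The expectation for compound 3 in this assay is therefore a number close to that of compound 2, estimated at 25000 nM, with a range from 8000 nM to 80000 nM. This estimate corresponds to an expected step of a 1.1-fold higher number from compound 2 to compound 3 (0.04 log units; within the scatter), not beyond the scatter.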

Compound 3, half-maximal inhibitory concentration: 22000 nM
Compound 3: middle estimate off by 1.1-fold (0.06 log units), on the high side; measured number inside the range.
By their numbers in this assay, from the lowest: compounds 3, 2 and 1 (each within the scatter of the next).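

At this carbon of the six-membered aromatic ring of carbon only, nitro and methyl cannot be told apart in this assay (a 1.0-fold lower number from compound 2 to compound 3 (0.02 log units; within the scatter)), even though nitro brings 3 heavy atoms and 2 hydrogen-bond acceptors where methyl brings 1 heavy atom and 0 hydrogen-bond acceptors. Nitro in place of hydrogen also stays within the scatter (a 1.9-fold lower number from compound 1 to compound 3 (0.28 log units; within the scatter)), so hydrogen, methyl and nitro now give numbers that cannot be separated, where the earlier step could say this only of methyl against hydrogen. No measurement at hand bears on why the number holds still across these three groups.

From the compounds shown here alone, whether any group at this carbon can move the number beyond the scatter remains open, for instance an amine, a carboxylic acid or a longer chain. Going by these compounds, the three compounds are identical everywhere outside this one carbon, so what a change elsewhere on the core of compound 1 would do to the number also stays open.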